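Small ring substituents on the phenol of compound 1

A few compounds are considered here, and "the series" means these few. Any claim that something is new, unique, unknown or untested is made for them only; others in the source may bear on it.

Measured so far:
compound 1 `O=C(c1cccnc1)c1ccccc1O` — 31000 nM
compound 2 `C=CCOc1c(Cl)cccc1C(=O)c1cccnc1` — 92000 nM
compound 3 `O=C(c1cccnc1)c1ccc(Br)cc1O` — 85000 nM

In a functional assay on Hep cells (Homo sapiens) for cytotoxicity, read by sulforhodamine B assay, with a stated time of 48 h (a lower number here means a stronger inhibitor, a higher number a weaker inhibitor), compound 1 gives the lowest of the three numbers; compound 3 sits nearest and compound 2 furthest, both beyond the scatter. Compound 4 `Cc1ccc(O)c(C(=O)c2cccnc2)c1` differs from compound 1 by methyl in place of hydrogen on an aromatic carbon. For the measured compounds named here, the only measured step that bears on it is a substituent entering the same ring: a 2.7-fold higher number from compound 1 to compound 3 (0.44 log units; beyond the scatter). That step went upward by a modest amount, so a step of similar size, or none beyond the scatter, is expected for a 1.5-fold higher number from compound 1 to compound 4 (0.16 log units; within the scatter). Compound 4 is therefore estimated at 45000 nM, with a range from 20000 nM to 100000 nM.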

Compound 4, half-maximal inhibitory concentration: 11000 nM
Estimate against measurement, compound 4: 4.1-fold (0.61 log units) above, and the stated range ends above it.
By their numbers in this assay, from the lowest: compound 4; then compound 1; then compounds 3 and 2 (each within the scatter of the next).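

In this assay, methyl on the aromatic carbon para to the hydroxy group gives a 2.8-fold lower number from compound 1 to compound 4 (0.45 log units; beyond the scatter), so a substituent on this ring need not raise the number, as bromo did with a 2.7-fold higher number from compound 1 to compound 3 (0.44 log units; beyond the scatter). The two steps differ in both the group and the ring carbon, so neither factor can be isolated. No available evidence accounts for the drop. Still open, going by these compounds, is whether the lower number belongs to methyl itself or to this carbon. Ethyl, methoxy or an amine at the same carbon would bear on that.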